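The compounds below may be only part of what the source reports. "The series", "measured", "known", "first", "only" and "open" are said of these compounds alone.

Measured in a functional assay on GOTO cells (Homo sapiens) for cytotoxicity, read by MTT assay, with a stated time of 3 days; on this read-out higher numbers stand for weaker inhibition and lower numbers for stronger inhibition:

- Compound 1 `N#Cc1c(Cl)nc(SCc2nc3ccccc3[nH]2)nc1-c1ccccc1`: 8.62 nM
- Compound 2 `N#Cc1c(Nc2nccs2)nc(SCc2nc3ccccc3[nH]2)nc1-c1ccccc1`: 5.1 nM
- Compound 3 `N#Cc1c(NNC(N)=S)nc(SCc2nc3ccccc3[nH]2)nc1-c1ccccc1`: 2.55 nM

Compound 3, at 2.55 nM, has a clearly lower number than compound 1 only: a 3.4-fold lower number from compound 1 to compound 3 (0.53 log units; beyond the scatter). Its gap to compound 2 stays within the usual scatter: a 2.0-fold lower number from compound 2 to compound 3 (0.30 log units; within the scatter).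

The next compound is compound 4 `CN1CCN(c2nc(SCc3nc4ccccc4[nH]3)nc(-c3ccccc3)c2C#N)CC1`. The change is a group of 7 heavy atoms (5 carbon, 2 nitrogen; one six-membered non-aromatic ring with 2 hetero atoms) in place of a group of 5 heavy atoms (1 carbon, 3 nitrogen, 1 sulfur; no ring), on an aromatic carbon. The entering group is 4-methylpiperazin-1-yl, on the same aromatic carbon, ortho to a cyano group.

Swaps at this carbon have so far moved the number only a little: a 1.7-fold lower number from compound 1 to compound 2 (0.23 log units; within the scatter), as well as the two steps above. Among the measured compounds shown here, no measured compound carries the 4-methylpiperazin-1-yl group, so there is no direct precedent for it. A modest move is therefore the best guess, and since compound 3 sits at 2.55 nM, at the low end of the measured numbers, any move is more likely upward than downward. The expected step, probably within the scatter, is a 1.8-fold higher number from compound 3 to compound 4 (0.25 log units; within the scatter). For compound 4 the estimated value in this assay is 4.5 nM, with an expected range from 1.5 nM to 13 nM.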

Compound 4, half-maximal inhibitory concentration: 3.37 nM
Compound 4: the middle estimate sits 1.3-fold (0.13 log units) above what was measured, and the stated range covers the measured number.
By their numbers in this assay, from the lowest: compounds 3, 4, 2 and 1 (each within the scatter of the next, the first and the last beyond it).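

In this assay, among the compounds shown here, 4-methylpiperazin-1-yl is the only group at this aromatic carbon with a six-membered non-aromatic ring, and it takes the place of a group with 3 hydrogen-bond donors while bringing 0 of its own. Even so, compound 4 stays within the scatter of both other nitrogen-bearing compounds (a 1.3-fold higher number from compound 3 to compound 4 (0.12 log units; within the scatter)) (a 1.5-fold lower number from compound 2 to compound 4 (0.18 log units; within the scatter)). Against chloro, the step is beyond the scatter (a 2.6-fold lower number from compound 1 to compound 4 (0.41 log units; beyond the scatter)), as it is for compound 3 but not for compound 2 (a 1.7-fold lower number from compound 1 to compound 2 (0.23 log units; within the scatter)), and no measurement shown explains why such different groups give such close numbers.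

From the compounds shown here alone, whether the methyl group matters stays open, and a plain piperazine or a morpholine at this carbon would test that. Going by these compounds, it is also open whether a carboxylic acid there would keep the number in this range.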